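Aryl variation on the shared core: toward a sulfamoyl phenyl

The compounds below may be only part of what the source reports. "The series", "measured", "known", "first", "only" and "open" are said of these compounds alone.

Compound 3 `CCCS(=O)(=O)Nc1ccc(F)c(C(=O)c2n[nH]c3ncc(-c4ccc(F)cc4C)cc23)c1F` gives 14% in an assay for binding affinity to dual specificity mitogen-activated protein kinase kinase 4 (Homo sapiens), read by KINOMEscan, tested at 100 nM; a higher number here means a weaker effect of the compound at the concentration tested, a lower number a stronger effect. Among the three measured compounds it stands second highest: compound 1 `CCCS(=O)(=O)Nc1ccc(F)c(C(=O)c2n[nH]c3ncc(-c4cccc(F)c4)cc23)c1F` gives 8.2% and compound 2 `CCCS(=O)(=O)Nc1ccc(F)c(C(=O)c2n[nH]c3ncc(-c4ccc(C)c(C)c4)cc23)c1F` gives 20%, so compound 3 sits within the scatter of both, a number 5.8 percentage points higher from compound 1 to compound 3 (within the scatter) and a number 6 percentage points lower from compound 2 to compound 3 (within the scatter).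

The next compound, compound 4 `CCCS(=O)(=O)Nc1ccc(F)c(C(=O)c2n[nH]c3ncc(-c4ccc(S(=O)(=O)NC)cc4)cc23)c1F`, is not yet measured. It differs from compound 3 in one place: 4-(methylsulfamoyl)phenyl in place of 4-fluoro-2-methylphenyl on an aromatic carbon.

Every measured step varies the same aryl ring on the core. Within the data shown here, the only step beyond the scatter is a number 11.8 percentage points higher from compound 1 to compound 2 (beyond the scatter), a modest one; the others are within the scatter. Among the measured compounds shown here, no measured step introduces a sulfamoyl group or a hydrogen-bond donor at this position, so the bearing of these steps is indirect. The expectation is a step of similar or smaller size, direction uncertain, a number 2 percentage points higher from compound 3 to compound 4 (within the scatter). Compound 4 is therefore estimated at 16%, with a range from 4% to 42%.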

Compound 4, a percentage reported as activity, at one concentration (the size of the read-out at that concentration, not a potency): 1.2%
Beside the measured number, compound 4's estimate is 14.8 percentage points above it; the measured number lies below the stated range.
By their numbers in this assay, from the lowest: compounds 4, 1, 3 and 2 (each within the scatter of the next, the first and the last beyond it).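

At this position on the shared core, 4-(methylsulfamoyl)phenyl is the only aryl group shown with a hydrogen-bond donor, and in this assay it gives a number 12.8 percentage points lower from compound 3 to compound 4 (beyond the scatter) and a number 18.8 percentage points lower from compound 2 to compound 4 (beyond the scatter) as modest steps toward a stronger effect. Against the 3-fluorophenyl of compound 1 there is a number 7 percentage points lower from compound 1 to compound 4 (within the scatter) and so no separation, which means the larger sulfamoyl-bearing aryl group is accepted here without loss of effect but is not shown to outperform every smaller aryl group. No measurement or other evidence shown here accounts for the change.

On these data alone, whether the hydrogen on the sulfamoyl nitrogen or the sulfonyl part goes with the lower number stays open; a dimethylsulfamoyl, a carboxylic acid or an amine on the same phenyl would help to separate these. These single-concentration read-outs also give no potency for any of the compounds.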